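The source may report more compounds than this note shows. Statements on the series, on what has been measured and on what is new or still open speak of the compounds shown alone.

Three compounds have been measured in a functional assay on HepG2 cells (Homo sapiens) for antiproliferative activity, read by CCK-8 assay, with a stated time of 72 h, tested at 8 uM; a higher number here means a stronger effect of the compound at the concentration tested, a lower number a weaker effect:

Compound 1 `CCCCn1cnc2c(NCc3ccc(C(=O)Nc4ccccc4N)cc3)nc(Cl)nc21`: 19.6%
Compound 2 `Nc1ccccc1NC(=O)c1ccc(CNc2nc(Cl)nc3c2ncn3C2CCCC2)cc1`: 74.9%
Compound 3 `CCCCn1cnc2c(Nc3cccc(Cl)c3)nc(NCOCc3ccc(C(=O)Nc4ccccc4N)cc3)nc21`: 63.1%

Compound 2 differs from compound 1 by one change, (cyclopentyl in place of butyl on an aromatic nitrogen), and this change made a step of a number 55.3 percentage points higher from compound 1 to compound 2 (beyond the scatter). Compound 3 differs from compound 1 in more than one place, so the difference between the two cores is not broken down here; in this assay compound 3 stands second of the three, with compound 2 the nearest to it and compound 1 the furthest.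

Compound 4 `Nc1ccccc1NC(=O)c1ccc(COCNc2nc(Nc3cccc(Cl)c3)c3ncn(C4CCCC4)c3n2)cc1` has not yet been measured. It differs from compound 3 by cyclopentyl in place of butyl on an aromatic nitrogen, and the place of the change reads the same word for word as for the change from compound 1 to compound 2, so it is the same change. Because the earlier step was a number 55.3 percentage points higher from compound 1 to compound 2 (beyond the scatter), a rise is expected for compound 4 as well, though compound 3 already starts from a high value and the read-out cannot go far above it. The step expected from compound 3 to compound 4 is a number 21.9 percentage points higher from compound 3 to compound 4 (beyond the scatter). For compound 4 the estimate in this assay is 85%, between 65% and 97%.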

Compound 4, a percentage reported as inhibition, at one concentration (the size of the read-out at that concentration, not a potency): 63.2%
Beside the measured number, compound 4's estimate is 21.8 percentage points above it; measured number outside the range, below it.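

In this assay, the step for cyclopentyl in place of butyl on an aromatic nitrogen was a number 0.1 percentage points higher from compound 3 to compound 4 (within the scatter), so on the core of compound 3 this change left the read-out level. The change therefore did not carry its size over from one core to the other: the same change on two cores in this assay, a number 55.3 percentage points higher (beyond the scatter) from compound 1 to compound 2 and a number 0.1 percentage points higher (within the scatter) from compound 3 to compound 4, 55.2 percentage points apart, beyond the scatter of two such steps. Going by these compounds alone, this shows that, in this series, a step seen on one core cannot simply be transferred to another, but with only two pairs it does not show which of the differences between the cores accounts for the gap, and a read-out at one concentration says nothing about potency.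

The compounds shown leave open whether a longer chain such as hexyl, or a cyclohexyl group, on the same aromatic nitrogen would follow the large step or the level one. Also open, as far as these compounds go, is which of the two results a further pair on a third core would resemble.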